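Trifluoromethyl on the 3-hydroxybutyl chain

This account rests on a few compounds, and the source may have more. Where it says the series, first, only, none or still open, it means among the compounds named here.

Values in an in vitro ADME assay on microsomes from Gut (Homo sapiens) for metabolic stability, in the presence of a further agent that is not named here (a higher number here means faster removal of the compound, a lower number slower removal), so far:
- compound 1 `CC(C)(O)CCNC(=O)c1cc2cc(C#N)ccc2n1Cc1cccc(OC(F)(F)F)c1` gives 9 mL.min-1.g-1
- compound 2 `CC(O)CCNC(=O)c1cc2cc(C#N)ccc2n1Cc1cccc(OC(F)(F)F)c1` gives < 6 mL.min-1.g-1 as a limit

Compound 2 stands at the limit of < 6 mL.min-1.g-1 in this assay, at which 1 of the 2 values shown sits, and so has a limit, not a number. Compound 3 `N#Cc1ccc2c(c1)cc(C(=O)NCCC(O)C(F)(F)F)n2Cc1cccc(OC(F)(F)F)c1` carries 4,4,4-trifluoro-3-hydroxybutyl in place of 3-hydroxybutyl trifluoromethyl in place of methyl on a saturated chain carbon bound to an oxygen on a saturated carbon and a saturated chain carbon on the shared core. For the measured compounds named here, the one measured step on this chain is an at least 1.5-fold lower number from compound 1 to compound 2 (0.17 log units; that floor lies within the scatter) and it concerns a methyl, not a trifluoromethyl, so it bears only loosely. With that step alone to go on, the expected step of a number no lower from compound 2 to compound 3 (the limit leaves the size open) in this assay is none beyond the scatter. For compound 3 the estimate is 6 mL.min-1.g-1 with an expected range of 4 mL.min-1.g-1 to 12 mL.min-1.g-1 in this read-out.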

Compound 3, intrinsic clearance in microsomes: < 6 mL.min-1.g-1
Compound 3: only a limit was reported (the forecaster's own chance of this, stated with the estimate: 55%); the middle value sits exactly at the limit.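

In this assay compound 3 has a limit, not a number, and the step between compound 2 and compound 3 cannot be read: the limit of < 6 mL.min-1.g-1 in this assay, at which 2 of the 3 values shown sit. Trifluoromethyl in place of methyl on this saturated chain carbon bound to an oxygen therefore leaves the compound at that same limit. 2,2,2-Trifluoro-1-hydroxyethyl in place of 1-hydroxy-1-methylethyl gives an at least 1.5-fold lower number from compound 1 to compound 3 (0.17 log units; that floor lies within the scatter), so this comparison shows no firm separation.

Any real difference between the methyl and trifluoromethyl compounds remains hidden behind the limit. Also open, going by these compounds, is how this chain reads with an amine or a carboxylic acid in place of the hydroxyl.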